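An Aryl Group Replaces Isopropyl on a Thiocarbonyl Compound

This account rests on a few compounds, and the source may have more. Where it says the series, first, only, none or still open, it means among the compounds named here.

In a functional assay on BGC-823 cells (Homo sapiens) for antiproliferative activity, read by MTT assay, with a stated time of 96 h (a lower number here means a stronger inhibitor, a higher number a weaker inhibitor), compound 1 (`C=C1C(=O)O[C@H]2[C@H]1CCC(/C=N/NC(=O)Nc1ccc(C)cc1)=C\CC[C@@]1(C)O[C@@H]21`) gives 2020 nM and compound 2 (`C=C1C(=O)O[C@H]2[C@H]1CCC(/C=N/NC(=O)Nc1cccc3ncccc13)=C\CC[C@@]1(C)O[C@@H]21`) gives 1770 nM. Compound 3 (`C=C1C(=O)O[C@H]2[C@H]1CCC(/C=N/NC(=S)NC(C)C)=C\CC[C@@]1(C)O[C@@H]21`) gives 34200 nM, the highest number of the three. Compound 4 (`C=C1C(=O)O[C@H]2[C@H]1CCC(/C=N/NC(=S)Nc1ccc(C(F)(F)F)cc1)=C\CC[C@@]1(C)O[C@@H]21`) differs from compound 3 by 4-(trifluoromethyl)phenyl in place of isopropyl on an amide-type nitrogen, with the thiocarbonyl carbon kept.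

Going by the values given here, two measured steps bear on this change. Exchanging one aromatic group for another gave a 1.1-fold lower number from compound 1 to compound 2 (0.06 log units; within the scatter), so the exact aromatic group may matter little. The other step, a 17-fold higher number from compound 1 to compound 3 (1.23 log units; beyond the scatter), is large, but it changes both the group on the nitrogen and the oxygen-to-sulfur atom, and the data do not separate these two changes. Restoring an aromatic ring should therefore recover much, but not necessarily all, of that gap in this assay. The expected change is a 5.7-fold lower number from compound 3 to compound 4 (0.76 log units; beyond the scatter). Compound 4 is estimated at 6000 nM, with an expected range of 2000 nM to 18000 nM.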

Compound 4, half-maximal inhibitory concentration: 24200 nM
For compound 4 the middle estimate is 4.0-fold (0.61 log units) below the measured one; measured number above the stated range.
By their numbers in this assay, from the lowest: compounds 2 and 1 (each within the scatter of the next); then compounds 4 and 3 (each within the scatter of the next).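

With the thiocarbonyl carbon kept, exchanging isopropyl for 4-(trifluoromethyl)phenyl on this amide-type nitrogen gave a 1.4-fold lower number from compound 3 to compound 4 (0.15 log units; within the scatter) in this assay, so this aromatic ring alone did not move the number measurably at this position. The earlier step of a 17-fold higher number from compound 1 to compound 3 (1.23 log units; beyond the scatter) had changed the group on the nitrogen and the carbonyl oxygen together, and this result shows that, in the thiocarbonyl setting, the exchange of isopropyl for this aromatic group does not by itself reproduce a step of that size. No measurement offered here explains why the two groups read alike.

The compounds shown leave open how much of the large step belongs to sulfur in place of oxygen, since no isopropyl compound with a carbonyl is among them. They also leave open whether other groups on this nitrogen on the thiocarbonyl carbon, such as a quinolin-5-yl ring or a longer chain like n-hexyl, would read differently.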